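A few compounds are considered here, and "the series" means these few. Any claim that something is new, unique, unknown or untested is made for them only; others in the source may bear on it.

In an ADME assay on BaF3 cells (Mus musculus) for cytotoxicity (a lower number here means that less compound is needed, a higher number that more compound is needed for the effect), compound 1 `Cc1nc(C)c(Cn2ncc3c(Nc4ccc(OC(F)(F)F)cc4)ncnc32)s1` gives > 10000 nM, which is a limit of the assay rather than a measured number. Compound 2 `FC(F)(F)c1ccc(Nc2cc(-c3ccncc3)ncn2)cc1` gives > 10000 nM, also a limit. Compound 3 `NC(=O)c1ccccc1-c1cc(Nc2ccc(OC(F)(F)F)cc2)ncn1` gives > 10000 nM, a limit as well. (the limit of > 10000 nM in this assay, at which 3 of the 3 values shown sit), so none of the three compounds has shown a measurable effect in this assay. Compound 4 `FC(F)(F)Oc1ccc(Nc2ncnc3c2cnn3C2CCCCC2)cc1` has not been tested yet; it differs from compound 1 by cyclohexyl in place of (2,4-dimethyl-1,3-thiazol-5-yl)methyl on an aromatic nitrogen. Among the measured compounds shown here, no measured pair of compounds differing in a single place exists here, so the size of this change cannot be read off other steps. The expected step that the limit leaves unreadable from compound 1 to compound 4 is none beyond the scatter. Compound 4 is therefore estimated at 15000 nM, within 7000 nM to 40000 nM, most likely again only a limit.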

Compound 4, half-maximal effective concentration: 9300 nM
Compound 4: the middle estimate sits 1.6-fold (0.21 log units) above what was measured; the range from low to high includes it.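

Among the compounds shown here, with cyclohexyl on the aromatic nitrogen, compound 4 gives the first true number in this assay (9300 nM), so an effect on these cells can be read at this position. Compound 1 gives > 10000 nM as a limit of the assay, and such limits dominate: (the limit of > 10000 nM in this assay, at which 3 of the 4 values shown sit). The swap of (2,4-dimethyl-1,3-thiazol-5-yl)methyl for cyclohexyl can therefore be stated only as a floor (an at least 1.0-fold lower number from compound 1 to compound 4 (0.03 log units; that floor lies within the scatter)), and its true size cannot be read.

Still open, from the compounds shown here alone, is how an amine or a longer chain on this nitrogen would compare with cyclohexyl.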